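The source may hold more compounds than are shown below. What is called first, only, known or untested is meant among the compounds shown, and "the series" means these compounds.

Measured so far:
compound 1, `COc1ccc(C(CC(=O)O)NC(=O)NNC(=O)c2cccc(NC(=N)N)c2)cc1`, 0.58
compound 2, `N=C(N)Nc1cccc(C(=O)NNC(=O)NC(CC(=O)O)c2cc(Cl)cc(Cl)c2)c1`, 1.82
compound 3, `COc1ccc(C(CC(=O)O)CC(=O)NNC(=O)CCCCNc2ccccn2)cc1`, 1.94

These values come from a physicochemical assay for lipophilicity; on this read-out lower numbers stand for lower lipophilicity and higher numbers for higher lipophilicity. Compound 1 and compound 2 share one core and differ in a single place: 3,5-dichlorophenyl in place of 4-methoxyphenyl on a saturated chain carbon bound to an amide-type nitrogen and a saturated chain carbon. This change produced a number 1.24 log units higher from compound 1 to compound 2 (beyond the scatter). Compound 3 is built on a different core; how the core of compound 3 differs from the core of compound 1 is not broken down here. In this assay compound 3 gives 1.94 and compound 2 gives 1.82, two values that lie within the scatter of each other, so nothing separates them.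

Compound 4, `O=C(O)CC(CC(=O)NNC(=O)CCCCNc1ccccn1)c1cc(Cl)cc(Cl)c1`, has not yet been measured. It relates to compound 3 the way compound 2 relates to compound 1: 3,5-dichlorophenyl in place of 4-methoxyphenyl on a saturated chain carbon bound to two saturated chain carbons. The surroundings are not identical, though. In compound 1 the exchanged group sits on a saturated chain carbon bound to an amide-type nitrogen and a saturated chain carbon, whereas in compound 3 it sits on a saturated chain carbon bound to two saturated chain carbons. Going by the values given here, it is therefore the same kind of change rather than the same change, and only one measured example of it exists, the pair of compound 1 and compound 2. In this assay the expected step is a number 1.24 log units higher from compound 3 to compound 4 (beyond the scatter), resting on that single earlier example, a number 1.24 log units higher from compound 1 to compound 2 (beyond the scatter). Compound 4 is estimated at 3.18, expected to fall between 2.6 and 3.7.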

Compound 4, partition coefficient: 3.19
For compound 4 the middle estimate is 0.01 log units below the measured one, within the range that was stated.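

In this assay, 3,5-dichlorophenyl in place of 4-methoxyphenyl gives a number 1.25 log units higher from compound 3 to compound 4 (beyond the scatter), which has the same direction and nearly the same size as the earlier step, a number 1.24 log units higher from compound 1 to compound 2 (beyond the scatter), so within these two pairs the change carried over from one core to the other even though its immediate surroundings differ. Going by these compounds alone, this shows agreement between only two pairs, and it does not show that the step would keep its size on a third core, at another place on the molecule, or with any other exchange of groups. Nothing available here accounts for the close match between the two steps, so it stands as an observation without an explanation.

The compounds shown leave open how each step divides between losing the 4-methoxyphenyl group's methoxy and gaining the two chlorines, as both happen in a single exchange. An unsubstituted phenyl group at the same place would separate those two parts, and a cyclohexyl group would test whether the step depends on having an aromatic ring there at all.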